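Chloro to cyano on the aryl ring of compound 1

This account rests on a few compounds, and the source may have more. Where it says the series, first, only, none or still open, it means among the compounds named here.

Compound 1 `CCOC(=O)c1sc(NC(=O)Cn2cc(-c3ccc(Cl)cc3)nn2)nc1C` gives 180 nM in a functional assay on BMDM cells (Mus musculus, strain C57BL/6) for inhibition, with a stated time of 2 days; on this read-out lower numbers stand for stronger inhibition and higher numbers for weaker inhibition. Of the two numbers reported in this assay, compound 1 has the lowest; its nearest neighbour is compound 3 `Cc1csc(NC(=O)Cn2cc(-c3ccc(Cl)cc3)nn2)n1`, which gives 520 nM, and the change from compound 1 to compound 3, hydrogen in place of ethoxycarbonyl on an aromatic carbon, brings a 2.9-fold higher number from compound 1 to compound 3 (0.46 log units; beyond the scatter). Compound 2 `Cc1cc(NC(=O)Cn2cc(-c3ccccc3Cl)nn2)no1` is reported only as a limit of this assay, > 30000 nM; one of the three values sits at the limit of > 30000 nM in this assay, at which 1 of the 3 values shown sits.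

Compound 4 `CCOC(=O)c1sc(NC(=O)Cn2cc(-c3ccc(C#N)cc3)nn2)nc1C` differs from compound 1 by cyano in place of chloro on an aromatic carbon. Within the data shown here, no measured step touches this place on the phenyl ring: the only step in this assay changes the ethoxycarbonyl group instead, so it gives no direct guide. The change is small in count and leaves the shared core untouched, so compound 4 is expected to stay near compound 1, with a step of a 1.7-fold higher number from compound 1 to compound 4 (0.22 log units; within the scatter) that may lie within the scatter. Compound 4 is therefore estimated at 300 nM in this assay, within 100 nM to 1200 nM.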

Compound 4, half-maximal inhibitory concentration: 310 nM
Compound 4: the middle estimate sits 1.0-fold (0.01 log units) below what was measured, and the stated range covers the measured number.
By their numbers in this assay, from the lowest: compounds 1, 4 and 3 (each within the scatter of the next, the first and the last beyond it). At a limit, above all of these: compound 2.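

Among these compounds, compound 4 gives the first measured step at the aryl group: in this assay, cyano in place of chloro on an aromatic carbon brings a 1.7-fold higher number from compound 1 to compound 4 (0.24 log units; within the scatter), so on this read-out 4-chlorophenyl and 4-cyanophenyl cannot be told apart. This place therefore takes cyano as well as chloro with the rest of compound 1 held fixed, whereas the step at the ethoxycarbonyl group, a 2.9-fold higher number from compound 1 to compound 3 (0.46 log units; beyond the scatter), lies beyond the scatter. Nothing measured on these compounds accounts for how closely the two groups agree.

The compounds shown leave open how an amine, a carboxylic acid or a methoxy group would read at this same place on the ring. They also leave open whether cyano and chloro would agree as closely with hydrogen in place of ethoxycarbonyl, as in compound 3.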